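The source may report more compounds than this note shows. Statements on the series, on what has been measured and on what is new or still open speak of the compounds shown alone.

Compound 3 `N#Cc1ccc(C(=O)NC(=S)N2CCc3c(OCCCCCOc4ccc(Cl)cc4)cccc32)cc1` was examined in an ADME assay on Huh-7 cells (Homo sapiens) for cytotoxicity (a higher number here means that more compound is tolerated, a lower number that less compound is tolerated), where compound 3 gives > 50000 nM, which is a limit of the assay and not a number. Compound 1 `NC(=S)N1CCCc2c(OCCCCCOc3cccc4ccccc34)cccc21` likewise reaches only a limit in this assay, namely > 50000 nM. Compound 2 `O=C(NC(=S)N1CCc2cccc(OCc3ccccc3)c21)c1ccccc1` also stops at a limit in this assay, namely > 50000 nM. Compound 3 thus stands at the limit of > 50000 nM in this assay, at which 3 of the 3 values shown sit, with no measured number that would set it apart from the other two. Compound 4 `CC(C)(C)c1ccc(C(=O)NC(=S)N2CCc3c(OCCCCCOc4ccc(Cl)cc4)cccc32)cc1` differs from compound 3 by tert-butyl in place of cyano on an aromatic carbon. Because every value shown sits at the limit of > 50000 nM in this assay, at which 3 of the 3 values shown sit, no step beyond the usual scatter is expected for a number no higher from compound 3 to compound 4 (the limit leaves the size open). Compound 4 is therefore expected to give about 50000 nM in this assay, within 20000 nM to 120000 nM, most likely again reported only as a limit.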

Compound 4, half-maximal cytotoxic concentration: > 50000 nM
Compound 4: only a limit was reported; the forecaster's own chance of this, stated with the estimate: 85%; the middle value sits exactly at the limit.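

Within the data shown here, compound 4 gives > 50000 nM in this assay, which is a limit and not a number, and compound 3 also stops at a limit, so no step between them can be read. The compounds shown leave open at what concentration any of them becomes toxic to the cells: the limit of > 50000 nM in this assay, at which 4 of the 4 values shown sit.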